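The source may report more compounds than this note shows. Statements on the series, on what has been measured and on what is new or still open speak of the compounds shown alone.

In an ADME assay (liver) for metabolic stability, with Liver microsome (Rattus norvegicus) as the target, using microsomes and NADPH, with a stated time of 30 min, tested at 1 uM (a higher number here means faster removal of the compound, a lower number slower removal), compound 1 `NC(=O)c1cccc(-c2cc(C(O)(C(F)(F)F)C(F)(F)F)cnc2N2CCN(S(=O)(=O)c3ccc(N)nc3)CC2)c1` gives 63 mL.min-1.g-1 and compound 2 `Nc1ccc(S(=O)(=O)N2CCN(c3ncc(C(O)(C(F)(F)F)C(F)(F)F)cc3-c3cnccc3F)CC2)cn1` gives 22 mL.min-1.g-1 as the lower of the two numbers. Compound 3 `Nc1ccc(S(=O)(=O)N2CCN(c3ncc(C(O)(C(F)(F)F)C(F)(F)F)cc3-c3cncc(F)c3)CC2)cn1` differs from compound 2 by 5-fluoropyridin-3-yl in place of 4-fluoropyridin-3-yl on an aromatic carbon with 5-fluoropyridin-3-yl in place of 4-fluoropyridin-3-yl on an aromatic carbon. Among the measured compounds shown here, the only measured step bearing on this is a 2.9-fold lower number from compound 1 to compound 2 (0.46 log units; beyond the scatter) at that same carbon, and it exchanged a 3-carbamoylphenyl group rather than moving the fluorine. A smaller step, none beyond the scatter, is expected in this assay and its direction is open. The estimated move is a 1.2-fold higher number from compound 2 to compound 3 (0.07 log units; within the scatter) as a working figure. For compound 3 the estimate is 26 mL.min-1.g-1 with a range from 13 mL.min-1.g-1 to 52 mL.min-1.g-1 in this reading.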

Compound 3, intrinsic clearance in microsomes: 19 mL.min-1.g-1
Compound 3: middle estimate off by 1.4-fold (0.14 log units), on the high side; the range from low to high includes it.
By their numbers in this assay, from the lowest: compounds 3 and 2 (each within the scatter of the next); then compound 1.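

With 5-fluoropyridin-3-yl in place of 4-fluoropyridin-3-yl, this assay does not separate the two isomers: a 1.2-fold lower number from compound 2 to compound 3 (0.06 log units; within the scatter). The 5-fluoropyridin-3-yl group also stands apart from 3-carbamoylphenyl, with a 3.3-fold lower number from compound 1 to compound 3 (0.52 log units; beyond the scatter), so among these compounds the difference from compound 1 does not depend on which of the two fluoropyridines is present. Nothing available accounts for these numbers.

Going by these compounds, it remains open whether the fluorine or the ring nitrogen goes with the lower numbers. A plain pyridin-3-yl or a 3-fluorophenyl group on this carbon would separate the two.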